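A few compounds are considered here, and "the series" means these few. Any claim that something is new, unique, unknown or untested is made for them only; others in the source may bear on it.

Compound 2 `CCCCCCCCCCn1cc(/C=C/C(=O)c2ccc(NC(=O)CN3CCN(C(=O)OC(C)(C)C)CC3)cc2)nn1` in a functional assay on A549 cells (Homo sapiens) for inhibition, read by MTT assay (a lower number here means a stronger inhibitor, a higher number a weaker inhibitor), gives 45400 nM. Compound 1 `CCCCCCCCn1cc(/C=C/C(=O)c2ccc(NC(=O)CN3CCN(c4ccc([N+](=O)[O-])cc4)CC3)cc2)nn1` in this assay gives 45400 nM, level with compound 2 within the scatter. Compound 3 `CCCCCCCCCCn1cc(/C=C/C(=O)c2ccc(NC(=O)CN3CCN(c4ccc([N+](=O)[O-])cc4)CC3)cc2)nn1` has not been measured. From compound 2 to compound 3 the change is 4-nitrophenyl in place of tert-butoxycarbonyl on an amine nitrogen in a ring. Among the measured compounds shown here, no measured pair differs in this place alone. Because compound 1 already carries 4-nitrophenyl on the amine nitrogen in the ring and gives 45400 nM, the step is expected to stay within the scatter a 1.0-fold lower number from compound 2 to compound 3 (0.00 log units; within the scatter). Compound 3 is expected to give 45000 nM, between 15000 nM and 130000 nM.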

Compound 3, half-maximal inhibitory concentration: 64500 nM
Compound 3: middle estimate off by 1.4-fold (0.16 log units), on the low side; measured number inside the range.
By their numbers in this assay, from the lowest: compounds 1, 2 and 3 (each within the scatter of the next).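

In this assay, 4-nitrophenyl in place of tert-butoxycarbonyl on an amine nitrogen in a ring gives a 1.4-fold higher number from compound 2 to compound 3 (0.15 log units; within the scatter) and so leaves the number within the scatter at this position. The chain change, ethyl in place of hydrogen on a saturated chain carbon, eight bonds along the chain from an aromatic nitrogen, gives a 1.4-fold higher number from compound 1 to compound 3 (0.15 log units; within the scatter) and also stays within the scatter. No measurement offers an explanation for either step.

On these data alone, whether an amine or a carboxylic acid on that ring nitrogen, or a longer chain on the aromatic nitrogen, would move the number beyond the scatter remains open.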